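This account rests on a few compounds, and the source may have more. Where it says the series, first, only, none or still open, it means among the compounds named here.

Three compounds share one core and differ only in the group on a saturated chain carbon bound to an amide-type nitrogen in a ring. Compound 1 `O=C1CN(S(=O)(=O)c2cc3ccc(Cl)cc3s2)CCN1Cc1cc2[nH]cccc-2n1` in an assay on isolated protein for binding affinity to serine protease 1 (Homo sapiens) (a higher number here means a weaker inhibitor, a lower number a stronger inhibitor), gives only a limit, > 2900 nM. Compound 2 `O=C1CN(S(=O)(=O)c2cc3ccc(Cl)cc3s2)CCN1Cc1cc2cc[nH]cc-2n1` in this assay likewise gives only a limit, > 2900 nM. Compound 3 `O=C1CN(S(=O)(=O)c2cc3ccc(Cl)cc3s2)CCN1Cc1cc2cnccc2o1` in this assay also reaches only a limit, > 2900 nM. The steps a step that the two limits leave unreadable from compound 1 to compound 2 and a step that the two limits leave unreadable from compound 2 to compound 3 stay unreadable because of the limit of > 2900 nM in this assay, at which 3 of the 3 values shown sit. Compound 4 `Nc1[nH]ccc2nc(CN3CCN(S(=O)(=O)c4cc5ccc(Cl)cc5s4)CC3=O)cc1-2` is not yet measured in this assay; it differs from compound 2 by a group of 10 heavy atoms (7 carbon, 3 nitrogen; one five-membered aromatic ring with 1 hetero atom, one six-membered aromatic ring with 1 hetero atom) in place of a group of 9 heavy atoms (7 carbon, 2 nitrogen; one five-membered aromatic ring with 1 hetero atom, one six-membered aromatic ring with 1 hetero atom), on a saturated chain carbon bound to an amide-type nitrogen in a ring. With no readable step to lean on, compound 4 is expected to sit near the same limit, at an estimated 5000 nM (range 1500 nM to 20000 nM). That corresponds to an expected step that the limit leaves unreadable from compound 2 to compound 4.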

Compound 4, inhibition constant: > 2900 nM
Compound 4 gave a limit, no number; the forecaster's own chance of this, stated with the estimate: 70%; the middle value is on the limit's open side.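

Compound 4, like compound 1, compound 2 and compound 3, gives only a limit in this assay, so no step among them can be read: the limit of > 2900 nM in this assay, at which 4 of the 4 values shown sit.

The compounds shown leave open whether compound 1, compound 2, compound 3 and compound 4 differ at all in this assay.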